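The compounds below may be only part of what the source reports. "The series", "measured", "known", "first", "only" and "open" are said of these compounds alone.

Measured compounds, with their values in an ADME assay on RAW264.7 cells (Mus musculus) for cytotoxicity, read by MTT assay, with a stated time of 24 h; a higher number here means that more compound is tolerated, a lower number that less compound is tolerated:

Compound 1, `Cc1cccc(C2CC(c3ccc(Cl)c(Cl)c3)=NN2C2=NC(=O)CS2)c1`, gives 204000 nM.
Compound 2, `Cc1ccc(C2=NN(C3=NC(=O)CS3)C(c3ccccc3Cl)C2)cc1C`, gives 227000 nM.
Compound 3, `O=C1CSC(N2N=C(c3ccc(Cl)c(Cl)c3)CC2c2ccccc2Cl)=N1`, gives 143000 nM.

Compound 3 gives the lowest of the three numbers, but its gaps to the other two lie within the scatter: the step of a 1.4-fold lower number from compound 1 to compound 3 (0.15 log units; within the scatter) and the step of a 1.6-fold lower number from compound 2 to compound 3 (0.20 log units; within the scatter) are both of a size that repeated measurements of this kind may show by chance.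

Compound 4, `O=C1CSC(N2N=C(c3ccc(Cl)c(Cl)c3)CC2c2ccc(F)cc2)=N1`, has not yet been measured in this assay. It differs from compound 3 in one place: 4-fluorophenyl in place of 2-chlorophenyl on a saturated ring carbon. Going by the values given here, of the measured steps, only the one from compound 1 to compound 3 touches the same saturated ring carbon, and there a change of the aryl group at that place, a 1.4-fold lower number from compound 1 to compound 3 (0.15 log units; within the scatter), stayed within the scatter. The step from compound 2 to compound 3 concerns the other position and was likewise within the scatter. Nothing in the three numbers therefore points to a shift beyond the scatter, and the expected step is a 1.0-fold higher number from compound 3 to compound 4 (0.02 log units; within the scatter). For compound 4 the estimate in this assay is 150000 nM, with a range from 70000 nM to 320000 nM.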

Compound 4, half-maximal cytotoxic concentration: 139000 nM
Compound 4: the middle estimate sits 1.1-fold (0.03 log units) above what was measured; low and high end bracket the measured number.
By their numbers in this assay, from the lowest: compounds 4, 3, 1 and 2 (each within the scatter of the next).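

With the 3,4-dichlorophenyl group held fixed, the saturated ring carbon next to the ring nitrogen has now carried three different substituted phenyl groups in this assay. Placing 4-fluorophenyl there gives a 1.0-fold lower number from compound 3 to compound 4 (0.01 log units; within the scatter) when it replaces 2-chlorophenyl and a 1.5-fold lower number from compound 1 to compound 4 (0.17 log units; within the scatter) when it replaces 3-methylphenyl, so neither a change of substituent nor a change of its place on the phenyl ring has moved the number beyond the scatter at this carbon. No measurement is available that bears on the reason for this result.

As far as these compounds go, every group at this carbon so far is a substituted phenyl ring, so it remains open whether an amine, a carboxylic acid or a longer alkyl chain there would give a step beyond the scatter. From the compounds shown here alone, it is also open whether 4-fluorophenyl would behave the same way with 3,4-dimethylphenyl at the other position.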